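The compounds below may be only part of what the source reports. "The series", "measured", "known", "first", "only" and "open" are said of these compounds alone.

Two compounds of this series carry the same basic amine side chain on a benzyl-substituted pyrrolidine, with different acyl groups on the ring nitrogen's neighbour. Compound 1, `CN(C)CCCOc1ccc(CN2CC[C@H](NC(=O)c3ccncc3)C2)cc1`, is the simplest of them; in an assay on HEK293 cells for binding affinity to Urotensin-2 receptor (Homo sapiens), read by radioligand binding (on this read-out lower numbers stand for stronger inhibition and higher numbers for weaker inhibition), compound 1 returns only a limit of < 10000 nM, not a number. Among the compounds with values here, compound 2, `CC(C)C[C@H](NC(=O)c1ccc(Cl)c(Cl)c1)C(=O)N[C@H]1CCN(Cc2ccc(OCCCN(C)C)cc2)C1`, adds a leucine-derived spacer capped by a 3,4-dichlorophenyl carbonyl group, and in this assay compound 2 gives 126 nM, the only numerical value in hand, so it serves as the single point of reference.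

Compound 3, `CC(=O)N[C@@H](CC(C)C)C(=O)N[C@H]1CCN(Cc2ccc(OCCCN(C)C)cc2)C1`, keeps the whole of that arrangement except at the cap, where the change is methyl in place of 3,4-dichlorophenyl on a carbonyl carbon. Within the data shown here, no measured pair in the set shows the effect of such an exchange, so the expectation rests on the fact that a large aromatic group is replaced by a single carbon. The step from compound 2 to compound 3 is expected to be a clear loss of affinity, well beyond the scatter, of about a 40-fold higher number from compound 2 to compound 3 (1.60 log units; beyond the scatter). Compound 3 is therefore estimated at 5000 nM, with a likely range from 800 nM to 30000 nM.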

Compound 3, inhibition constant: 2510 nM
Compound 3: the middle estimate sits 2.0-fold (0.30 log units) above what was measured, within the range that was stated.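

In this assay, within the data shown here, methyl in place of 3,4-dichlorophenyl on a carbonyl carbon gives a 20-fold higher number from compound 2 to compound 3 (1.30 log units; beyond the scatter), the first measured step to show what this position is worth. With the rest of the structure unchanged, the group on this carbonyl carbon clearly matters for affinity, yet the large step does not remove measurable binding, as compound 3 still gives a number, 2510 nM. The step between compound 1 and compound 3 cannot be read, since compound 1 returns only a limit of the assay: the limit of < 10000 nM in this assay, at which 1 of the 3 values shown sits.

The compounds shown leave open whether the step belongs to the aromatic ring itself or to its two chlorine atoms, which leave together in this exchange. Plain phenyl, 4-chlorophenyl or cyclohexyl on the same carbonyl carbon would separate those two parts, and a longer chain such as n-butyl would show whether more carbon without a ring recovers any of the affinity.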